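Ketone aryl change: furan-2-yl to thiophen-2-yl

The compounds below may be only part of what the source reports. "The series", "measured", "known", "first", "only" and "open" are said of these compounds alone.

Measured so far in a functional assay on PC-3 cells (Homo sapiens) for cytotoxicity, read by MTT assay, with a stated time of 48 h; a lower number here means a stronger inhibitor, a higher number a weaker inhibitor:
compound 1 `COc1cc(-c2nnc3n2NC(c2cccs2)C(C(=O)c2ccc(C)cc2)S3)cc(OC)c1OC` gives 5090 nM
compound 2 `COc1cc(-c2nnc3n2NC(c2cccs2)C(C(=O)c2ccc(F)cc2)S3)cc(OC)c1OC` gives 27400 nM
compound 3 `COc1cc(-c2nnc3n2NC(c2ccco2)C(C(=O)c2ccco2)S3)cc(OC)c1OC` gives 58300 nM

Compound 3 stands at the highest number of the three and is the weakest inhibitor in this assay; its gap to compound 2 and its gap to compound 1 both lie beyond the scatter. Compound 4 `COc1cc(-c2nnc3n2NC(c2ccco2)C(C(=O)c2cccs2)S3)cc(OC)c1OC` differs from compound 3 in one place: thiophen-2-yl in place of furan-2-yl on a carbonyl carbon.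

Among the measured compounds shown here, the only single-point step measured so far is a 5.4-fold higher number from compound 1 to compound 2 (0.73 log units; beyond the scatter). That step also sits on the aryl ketone, but it changes a substituent on the ring rather than the ring itself, so it bears on the present change only by showing that the ketone aryl group can move the number by a modest amount. For the measured compounds named here, compound 1 and compound 3 differ in more than one place; their values show only that compound 1, with two rings unlike those of compound 3, sits far lower.

Going by the values given here, with no closer precedent, a modest step is expected for compound 4, leaning towards a lower number, as a 1.9-fold lower number from compound 3 to compound 4 (0.29 log units; within the scatter). Compound 4 is estimated at 30000 nM, with a range from 12000 nM to 70000 nM.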

Compound 4, half-maximal inhibitory concentration: 46200 nM
Compound 4: middle estimate off by 1.5-fold (0.19 log units), on the low side, within the range that was stated.
By their numbers in this assay, from the lowest: compound 1; then compounds 2, 4 and 3 (each within the scatter of the next, the first and the last beyond it).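

In this assay, thiophen-2-yl in place of furan-2-yl on a carbonyl carbon gives a 1.3-fold lower number from compound 3 to compound 4 (0.10 log units; within the scatter), so this assay does not separate these two five-membered aromatic rings at this position, at least with furan-2-yl elsewhere in the molecule. Among the compounds shown here, this is the first exchange of the ketone ring itself, and unlike the fluoro-for-methyl exchange on the ketone aryl ring, which gives a 5.4-fold higher number from compound 1 to compound 2 (0.73 log units; beyond the scatter), it stays within the scatter; a change at the ketone aryl group therefore need not move the number, although the two steps stand on different backgrounds and cannot be set against each other as a clean comparison. No measured evidence bears on what lies behind either step.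

The compounds shown leave open whether a six-membered ring on this carbonyl, such as pyridin-2-yl or 4-methylphenyl, would give a step beyond the scatter when furan-2-yl is kept elsewhere in the molecule. They also leave open how a ketone ring carrying an amine or a carboxylic acid would read in this series.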